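A Chloro for a Methoxy on the Benzyl Arm

This account rests on a few compounds, and the source may have more. Where it says the series, first, only, none or still open, it means among the compounds named here.

Of the compounds shown here, two of a shared core have been tested in a functional assay on cells (Cancer cell lines, Homo sapiens) for cytotoxicity, with a stated time of 48 h; a lower number here means a stronger inhibitor of growth, a higher number a weaker inhibitor of growth. Compound 1 `COc1ccc(CN2C(=O)/C(=C\c3cc(OC)c(OC)c(OC)c3)c3ccccc32)cc1` gives 10500 nM in this assay, the lower of the two numbers. Compound 2 `COc1cc(/C=C2\C(=O)N(C)c3ccc(Cl)cc32)cc(OC)c1OC` gives 24500 nM in this assay, a higher number that lies beyond the usual scatter. Going by the values given here, the two differ in more than one place, so no single step can be drawn between them.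

Compound 3 `COc1cc(/C=C2\C(=O)N(Cc3ccc(Cl)cc3)c3ccccc32)cc(OC)c1OC` is not yet measured. It differs from compound 1 in one place: chloro in place of methoxy on an aromatic carbon.

Among the compounds with values here, with no step of this kind among the measured compounds, the expected change from compound 1 to compound 3 is estimated as a 1.2-fold lower number from compound 1 to compound 3 (0.07 log units; within the scatter), a step not clearly beyond the scatter in either direction. Compound 3 is therefore expected to give about 9000 nM in this assay, within the range 3000 nM to 30000 nM.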

Compound 3, concentration for total growth inhibition: 15100 nM
Estimate against measurement, compound 3: 1.7-fold (0.22 log units) below; the measured number falls inside the stated range.
By their numbers in this assay, from the lowest: compounds 1, 3 and 2 (each within the scatter of the next, the first and the last beyond it).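

The exchange of 4-methoxybenzyl for 4-chlorobenzyl provides the only single-place comparison among these compounds: in this assay, the step is a 1.4-fold higher number from compound 1 to compound 3 (0.16 log units; within the scatter). At this place, on an aromatic carbon para to a large group, the methoxy and chloro compounds therefore lie within the scatter of each other, and this assay does not separate the two groups there. The comparison covers this one pair of groups only, and nothing measured here offers an explanation for the result.

The compounds shown leave open how an amine, a carboxylic acid or a longer alkoxy chain at this same place would read in this assay. Going by these compounds alone, they also leave open whether the benzyl arm needs any group at this place, as no compound here carries a hydrogen there.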